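Carboxymethyl in place of carboxy on compound 3

A few compounds are considered here, and "the series" means these few. Any claim that something is new, unique, unknown or untested is made for them only; others in the source may bear on it.

In a functional assay on PC43-10 cells (Cricetulus griseus) for inhibition, read by CellTiter-Blue, with a stated time of 96 h (a lower number here means a stronger inhibitor, a higher number a weaker inhibitor), compound 1 (`Nc1nc2[nH]c(CCCCCC(=O)N[C@@H](CCC(=O)O)C(=O)O)cc2c(=O)[nH]1`) returns > 1000 nM as a limit and not as a number. Compound 2 (`Nc1nc2[nH]c(CCCCCCCCC(=O)N[C@@H](CCC(=O)O)C(=O)O)cc2c(=O)[nH]1`) likewise returns > 1000 nM as a limit. Compound 3 (`Nc1nc2[nH]c(CCCCCC(=O)O)cc2c(=O)[nH]1`) also stands at > 1000 nM as a limit and has no exact value. The whole record so far is the limit of > 1000 nM in this assay, at which 3 of the 3 values shown sit, and nothing more.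

Compound 4 (`Nc1nc2[nH]c(CCCCCCC(=O)O)cc2c(=O)[nH]1`) carries carboxymethyl in place of carboxy on a saturated chain carbon, five bonds along the chain from an aromatic carbon. Among the compounds with values here, no measured step yet shows what such a change does in this assay and no step beyond the scatter is expected. The expectation rests on compound 3 with its > 1000 nM as a limit. An estimated step that the limit leaves unreadable from compound 3 to compound 4 is therefore all that is expected. For compound 4 the estimated value is 1500 nM with an expected range from 500 nM to 5000 nM and a report of only a limit is the likeliest outcome.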

Compound 4, half-maximal inhibitory concentration: > 1000 nM
Compound 4: only a limit was reported; the forecaster's own chance of this, stated with the estimate: 85%; the middle value does not contradict the limit.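

No step can be read between compound 3 and compound 4, as this assay gives both only as limits. The compounds shown leave open how strongly any of them inhibits and whether chain length changes that, because none has an exact value: the limit of > 1000 nM in this assay, at which 4 of the 4 values shown sit.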